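Compound 3 to compound 4: a step without a start

The source may hold more compounds than are shown below. What is called first, only, known or untested is meant among the compounds shown, and "the series" means these compounds.

Values in a physicochemical assay for lipophilicity, read by HPLC, in phosphate buffer, measured as octanol-water partition, at pH 7.4, tested at 100 uM (on this read-out lower numbers stand for lower lipophilicity and higher numbers for higher lipophilicity), so far
- compound 1 (`CC(C)c1ccccc1-c1cccc(CNc2ccc(OCC(=O)O)c(F)c2)c1`) gives 3.45
- compound 2 (`N#Cc1ccccc1-c1cccc(CNc2ccc(OCC(=O)O)c(F)c2)c1`) gives "not determined" (no result reported)
- compound 3 (`COc1ccccc1-c1cccc(CNc2ccc(OCC(=O)O)c(F)c2)c1`) gives "not determined" (no result reported)

Compound 3 therefore stands without a single number in this assay and compound 2 shares that position. Only compound 1 offers a measured reading. Compound 4 (`Cc1cc(O)ccc1-c1cccc(CNc2ccc(OCC(=O)O)c(F)c2)c1`) has not yet been measured. The structural change is 4-hydroxy-2-methylphenyl in place of 2-methoxyphenyl on an aromatic carbon and in words it places 4-hydroxy-2-methylphenyl in place of 2-methoxyphenyl on an aromatic carbon, with the same atoms joined differently. For the measured compounds named here, no measured step between related compounds is available to serve as a guide, and the open entry for compound 3 leaves the starting point unknown. A moderate step towards lower numbers in this assay is nevertheless expected, somewhat beyond the usual scatter. Going by the values given here, the sole anchor is compound 1 at 3.45 and compound 4 is expected to fall under that reading. For compound 4 the estimated value is 2.4 with an expected range from 1.8 to 3 in this estimate.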

Compound 4, distribution coefficient: 1.85
For compound 4 the middle estimate is 0.55 log units above the measured one; the measured number falls inside the stated range.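

In this assay, for the compounds shown here, the exchange of 2-isopropylphenyl for 4-hydroxy-2-methylphenyl on an aromatic carbon gives the first readable step at this position, a number 1.60 log units lower from compound 1 to compound 4 (beyond the scatter). This shows that the reading at this position can move well beyond the scatter while the rest of the molecule stays the same; the step from compound 3 to compound 4 and any step from compound 2 cannot be read, as neither compound 2 nor compound 3 has a single number. Nothing available explains the size of this step.

The single step joins two exchanges, the arrival of the hydroxy group and the replacement of isopropyl by methyl, and the compounds shown do not separate them. From the compounds shown here alone, how an amine or a carboxylic acid on this ring would read also remains open.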